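Amide aryl variation on the shared core: compound 4

A few compounds are considered here, and "the series" means these few. Any claim that something is new, unique, unknown or untested is made for them only; others in the source may bear on it.

Measured compounds in a functional assay on HCC1937 cells (Homo sapiens) for antiproliferative activity, read by CCK-8 assay, with a stated time of 72 h; on this read-out higher numbers stand for weaker inhibition and lower numbers for stronger inhibition:
compound 1, `O=C(Nc1cccc(-c2oc3cc(-c4ccc(F)cc4)ccc3c(=O)c2O)c1)c1ccc(C(F)(F)F)cc1`, 7350 nM
compound 2, `Cc1cc(C(=O)Nc2cccc(-c3oc4cc(-c5ccc(F)cc5)ccc4c(=O)c3O)c2)ccc1F`, 5420 nM
compound 3, `COc1ccc(C(=O)Nc2cccc(-c3oc4cc(-c5ccc(F)cc5)ccc4c(=O)c3O)c2)c(F)c1`, 24500 nM

Compound 3 holds the highest number of the three. Its nearest neighbour is compound 1, its furthest compound 2, and both of these gaps lie beyond the scatter, so compound 3 is the weakest of the measured set. Compound 1 and compound 2 lie within the scatter of each other, as a 1.4-fold lower number from compound 1 to compound 2 (0.13 log units; within the scatter) shows.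

Compound 4, `O=C(Nc1cccc(-c2oc3cc(-c4ccc(F)cc4)ccc3c(=O)c2O)c1)c1cc(F)cc(F)c1`, is unmeasured. The change from compound 3 is 3,5-difluorophenyl in place of 2-fluoro-4-methoxyphenyl on a carbonyl carbon. For the measured compounds named here, two measured steps bear on it: the same position was already varied in a 3.3-fold higher number from compound 1 to compound 3 (0.52 log units; beyond the scatter) and in a 4.5-fold higher number from compound 2 to compound 3 (0.66 log units; beyond the scatter), both moving onto the 2-fluoro-4-methoxyphenyl group and both raising the number by a modest margin. Leaving that group for another aryl is therefore expected to reverse this, a modest lowering of the number toward the level of compound 1 and compound 2. Nothing measured speaks directly to 3,5-difluorophenyl, so the range is kept wide. For compound 4 in this assay the estimate is 8000 nM, between 3500 nM and 20000 nM, meaning an expected step of a 3.1-fold lower number from compound 3 to compound 4 (0.49 log units; beyond the scatter).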

Compound 4, half-maximal inhibitory concentration: 2070 nM
Estimate against measurement, compound 4: 3.9-fold (0.59 log units) above; the whole stated range lies above it.
By their numbers in this assay, from the lowest: compound 4; then compounds 2 and 1 (each within the scatter of the next); then compound 3.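

In this assay, for the compounds shown here, the aryl group on the amide carbonyl carbon spans more than the first three compounds showed, since a 12-fold lower number from compound 3 to compound 4 (1.07 log units; beyond the scatter) is a large step, whereas the earlier steps at this place were modest. The 3,5-difluorophenyl group does more than leave behind the high number of compound 3: with a 2.6-fold lower number from compound 2 to compound 4 (0.42 log units; beyond the scatter) and a 3.6-fold lower number from compound 1 to compound 4 (0.55 log units; beyond the scatter), both beyond the scatter, compound 4 passes the level shared by compound 1 and compound 2 and is the most potent of the four in this set. No measurement at hand explains this ordering among the four aryl groups.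

Open, from the compounds shown here alone, is whether the lower number depends on fluorine itself, which would be tested by replacing the two fluorines of the 3,5-difluorophenyl group with chlorine atoms, nitrile groups or methyl groups. Also open, going by these compounds, is whether the aryl ring is needed at all on the carbonyl carbon, or whether a pyridine ring or a saturated amine-bearing ring such as piperidine could stand in its place on the shared core.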